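The compounds below may be only part of what the source reports. "The series", "measured", "known", "first", "only" and "open" are said of these compounds alone.

In a functional assay on LNCaP cells (Homo sapiens) for antiproliferative activity, read by propidium iodide staining, with a stated time of 96 h (a higher number here means a weaker inhibitor, a lower number a stronger inhibitor), compound 1 `CC(O)(CSc1ccc(S(F)(F)(F)(F)F)cc1)C(=O)Nc1ccc([N+](=O)[O-])c(C(F)(F)F)c1` gives 8700 nM while compound 2 `CC(O)(CSc1ccc(F)cc1)C(=O)Nc1ccc(S(F)(F)(F)(F)F)cc1` gives 12500 nM and compound 3 `CC(O)(CS(=O)(=O)c1ccc(S(F)(F)(F)(F)F)cc1)C(=O)Nc1cccc(S(F)(F)(F)(F)F)c1` gives 11700 nM as its number. These three numbers all lie within the usual scatter of one another, so compound 3 stands level with the other two and no ranking can be drawn.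

Compound 4 `CC(O)(CS(=O)(=O)c1ccc(F)cc1)C(=O)Nc1cccc(S(F)(F)(F)(F)F)c1` is compound 3 with a single change. That change is one fluorine atom in place of a group of 6 heavy atoms (5 fluorine, 1 sulfur; no ring), on an aromatic carbon and it sits on an aromatic carbon of a six-membered aromatic ring of carbon only, para to a large group.

Among the measured compounds shown here, no two measured compounds differ in just one place, so no measured step isolates this swap. In this assay the expectation is therefore no step beyond the scatter, in either direction. That expectation leans on compound 2, which also carries a fluoro and gives 12500 nM in the same range as the others.

The estimated step is a 1.2-fold higher number from compound 3 to compound 4 (0.08 log units; within the scatter) on this reasoning. Compound 4 is expected at about 14000 nM with an estimated range of 6000 nM to 32000 nM around that middle.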

Compound 4, half-maximal inhibitory concentration: 32600 nM
Estimate against measurement, compound 4: 2.3-fold (0.37 log units) below; the whole stated range lies below it.
By their numbers in this assay, from the lowest: compounds 1, 3 and 2 (each within the scatter of the next); then compound 4.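

In this assay, among the compounds shown here, putting a fluoro in place of the group of 6 heavy atoms (5 fluorine, 1 sulfur) on an aromatic carbon, para to a large group, gives a 2.8-fold higher number from compound 3 to compound 4 (0.45 log units; beyond the scatter), the first step here that can be read in one place. It is a modest step, but it shows that this position is not indifferent to what it carries, and that for this one pair the larger group goes with the lower number. No measurement shown accounts for this step.

A hydrogen, a chlorine or a trifluoromethyl at this carbon would show whether the number follows group size or whether the group of 6 heavy atoms is a special case. From the compounds shown here alone, the steps among compounds 1, 2 and 3 cannot be read, so whether this swap acts alike on another core stays open.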